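Methoxy on the terminal ring of a diaryl diyne alcohol

A few compounds are considered here, and "the series" means these few. Any claim that something is new, unique, unknown or untested is made for them only; others in the source may bear on it.

Measured so far in a functional assay on K562 cells (Homo sapiens) for cytotoxicity; on this read-out lower numbers stand for stronger inhibition of growth and higher numbers for weaker inhibition of growth:
- compound 1, `OCCCCC#Cc1ccccc1C#Cc1ccccc1`: 21100 nM
- compound 2, `OCCCCC#Cc1ccccc1C#Cc1cccs1`: 20300 nM
- compound 3, `OCCCCC#Cc1ccccc1C#Cc1ccccc1C(F)(F)F`: 1100 nM

Compound 1 gives the highest of the three numbers. Compound 2 sits within the scatter of it, as the step of a 1.0-fold lower number from compound 1 to compound 2 (0.02 log units; within the scatter) shows. Compound 3 stands apart: the step of a 19-fold lower number from compound 1 to compound 3 (1.28 log units; beyond the scatter) is large and beyond the scatter.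

Compound 4, `COc1cccc(C#Cc2ccccc2C#CCCCCO)c1`, differs from compound 1 by methoxy in place of hydrogen on an aromatic carbon. For the measured compounds named here, the only measured step that touches the same terminal ring is the one from compound 1 to compound 3, which introduced a trifluoromethyl group rather than a methoxy and at a different place on that ring. The step to compound 2 says nothing about substituents on this ring. Going by the values given here, with no direct precedent for a methoxy at the place meta to a large group, only a modest step in this assay is expected for compound 4, leaning toward a lower number but well short of what compound 3 showed. The expected step is a 1.8-fold lower number from compound 1 to compound 4 (0.25 log units; within the scatter), giving an estimate for compound 4 of 12000 nM, in a range from 4000 nM to 30000 nM.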

Compound 4, concentration for 50% growth inhibition: 1800 nM
For compound 4 the middle estimate is 6.7-fold (0.82 log units) above the measured one; measured number outside the range, below it.
By their numbers in this assay, from the lowest: compounds 3 and 4 (each within the scatter of the next); then compounds 2 and 1 (each within the scatter of the next).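

In this assay, methoxy on an aromatic carbon meta to a large group gives a large change, a 12-fold lower number from compound 1 to compound 4 (1.07 log units; beyond the scatter), so this place on the terminal ring responds strongly to a small group of two heavy atoms. For the compounds shown here, until now the only large step on this ring was the trifluoromethyl one, a 19-fold lower number from compound 1 to compound 3 (1.28 log units; beyond the scatter), and it now has a second, different group beside it, which shows that a large step on this ring is not confined to trifluoromethyl. Nothing measured here accounts for why methoxy has this effect.

The compounds shown leave open whether methoxy keeps this step at other places on the ring, and whether trifluoromethyl would do the same at this place. They also leave open how an amine or a carboxylic acid would behave at this place.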